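A few compounds are considered here, and "the series" means these few. Any claim that something is new, unique, unknown or untested is made for them only; others in the source may bear on it.

In a functional assay on DU-145 cells (Homo sapiens) for inhibition, read by trypan blue exclusion, with a stated time of 96 h (a lower number here means a stronger inhibitor of growth, a higher number a weaker inhibitor of growth), compound 1 `COc1cc(/C=C(/Sc2ccc(Br)cc2)C(=O)c2ccc(Br)cc2)ccc1O` gives 1000 nM and compound 2 `O=C(/C(=C\c1ccc(F)cc1F)Sc1ccc(Br)cc1)c1ccc(Br)cc1` gives 1000 nM, so compound 2 stands level with compound 1. Still unmeasured is compound 3 `Nc1c(Br)cc(Br)cc1/C=C(/Sc1ccc(Br)cc1)C(=O)c1ccc(Br)cc1`, which keeps the rest of compound 2 and differs only on a double-bonded chain carbon bound to a double-bonded chain carbon: 2-amino-3,5-dibromophenyl in place of 2,4-difluorophenyl on a double-bonded chain carbon bound to a double-bonded chain carbon. There, 2-amino-3,5-dibromophenyl comes in place of 2,4-difluorophenyl. Among the measured compounds shown here, only one measured step bears on this place, the exchange no change at the digits printed from compound 1 to compound 2 (within the scatter), in which 2,4-difluorophenyl replaced 4-hydroxy-3-methoxyphenyl and the value stayed within the scatter. That is a single step, and neither measured compound carries the incoming group, so the evidence is thin. Even so, the one exchange seen at this place left this assay unmoved, and no large shift is expected here. The expected change is a 1.3-fold lower number from compound 2 to compound 3 (0.10 log units; within the scatter), which is no firm move in either direction beyond the scatter. For compound 3 the estimated value is 800 nM, with an expected range from 250 nM to 3000 nM.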

Compound 3, concentration for 50% growth inhibition: > 100000 nM
Compound 3: a limit, no number; the forecaster's own chance of this, stated with the estimate: 10%; middle value at least 120-fold (2.09 log units) away from the limit.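

In this assay, 2-amino-3,5-dibromophenyl on a double-bonded chain carbon bound to a double-bonded chain carbon gives an at least 100-fold higher number from compound 2 to compound 3 (2.00 log units; beyond the scatter), and the same group measured against the other earlier compound gives an at least 100-fold higher number from compound 1 to compound 3 (2.00 log units; beyond the scatter). Compound 3 stands at a limit and not at a number, so these steps give a bound and not an exact size: the limit of > 100000 nM in this assay, at which 1 of the 3 values shown sits. Among the compounds shown here, this place had looked indifferent while 4-hydroxy-3-methoxyphenyl and 2,4-difluorophenyl stood level, but compound 3 shows that the group here can matter a great deal, and that the single earlier exchange did not speak for all groups at this place.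

The incoming group differs from 2,4-difluorophenyl in both its amine and its two bromine atoms, so the compounds shown cannot tell which of these goes with the large step. Going by these compounds, a phenyl group carrying the amine without the bromine atoms, or the bromine atoms without the amine, would separate the two, and how far the number rises past the limit for compound 3 also stays open.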